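A few compounds are considered here, and "the series" means these few. Any claim that something is new, unique, unknown or untested is made for them only; others in the source may bear on it.

Series notes. Compound 1 `Cc1ccccc1-c1nn(-c2ccc(F)cc2F)cc1CN1CCN(c2ccccc2)CC1` in an ADME assay on Huh-7 cells (Homo sapiens) for cytotoxicity (on this read-out higher numbers stand for lower toxicity in this test and lower numbers for higher toxicity in this test), returns only a limit of the assay, > 20000 nM. Compound 2 `CN1CCN(CCNCc2cn(-c3ccc(F)cc3F)nc2Cc2ccccc2)CC1` in this assay likewise returns only a limit of the assay, > 20000 nM. Compound 3 `Cc1ccccc1-c1nn(-c2cccc(Cl)c2)cc1CNCCN1CCN(C)CC1` in this assay gives 16000 nM. Compound 2 therefore sits where most of the series sits, at the limit of > 20000 nM in this assay, at which 2 of the 3 values shown sit, with no number of its own. Going by the values given here, no pair of measured compounds differing in a single place is available, so no measured step can be quoted. Compound 4 `CN1CCN(CCNCc2cn(-c3ccc(F)cc3F)nc2C(C)(C)C)CC1` differs from compound 2 by tert-butyl in place of benzyl on an aromatic carbon. With two of three values at the limit and the third close to it, no step beyond the scatter is expected, and the estimated step is a number no higher from compound 2 to compound 4 (the limit leaves the size open). Compound 4 is expected to give 20000 nM, in the range 10000 nM to 40000 nM, most likely again as a limit.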

Compound 4, half-maximal cytotoxic concentration: > 20000 nM
Compound 4: no number, only a limit (the forecaster's own chance of this, stated with the estimate: 70%); the middle value lies on the limit itself.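

Compound 2 and compound 4 both return only a limit in this assay, so no step can be read for tert-butyl in place of benzyl. The compounds shown leave open how far either one lies from that limit, where most of the series sits: the limit of > 20000 nM in this assay, at which 3 of the 4 values shown sit.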